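Swapping the anilino ring toward a dimethoxy pattern

The source may hold more compounds than are shown below. What is called first, only, known or untested is meant among the compounds shown, and "the series" means these compounds.

Measured so far:
- compound 1 `COc1cc(Nc2nc3ccccc3nc2S(=O)(=O)c2ccccc2)cc(OC)c1`: 950 nM
- compound 2 `COc1ccc(Nc2nc3ccccc3nc2S(=O)(=O)c2ccc(F)cc2)cc1`: 3010 nM

Of the compounds shown here, two share one core and have been tested in a functional assay on HCT-116 cells (Homo sapiens) for cytotoxicity, read by MTT assay, with a stated time of 72 h; on this read-out higher numbers stand for weaker inhibition and lower numbers for stronger inhibition. Compound 1 `COc1cc(Nc2nc3ccccc3nc2S(=O)(=O)c2ccccc2)cc(OC)c1` gives 950 nM, and compound 2 `COc1ccc(Nc2nc3ccccc3nc2S(=O)(=O)c2ccc(F)cc2)cc1` gives 3010 nM. Of the two, compound 2 stands at the higher number, and the gap to compound 1 lies beyond the usual scatter of the read-out. The two compounds differ in two places at once, so their values alone cannot say which change matters.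

Compound 3 `COc1cc(Nc2nc3ccccc3nc2S(=O)(=O)c2ccc(F)cc2)cc(OC)c1` has not yet been measured. It differs from compound 2 in a single place: 3,5-dimethoxyphenyl in place of 4-methoxyphenyl on a nitrogen on an aromatic ring. This gives compound 3 the same anilino ring as compound 1 while it keeps the fluorinated sulfone of compound 2.

Given that compound 1 gives 950 nM with this same anilino ring, the expectation for compound 3 is a move toward a lower number in this assay, estimated as a 2.3-fold lower number from compound 2 to compound 3 (0.36 log units; beyond the scatter). The estimated value for compound 3 in this assay is 1300 nM, with a range from 500 nM to 3500 nM.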

Compound 3, half-maximal inhibitory concentration: 3930 nM
Beside the measured number, compound 3's estimate is 3.0-fold (0.48 log units) below it; the measured number lies above the stated range.
By their numbers in this assay, from the lowest: compound 1; then compounds 2 and 3 (each within the scatter of the next).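

In this assay, putting 3,5-dimethoxyphenyl in place of 4-methoxyphenyl on the nitrogen gives a 1.3-fold higher number from compound 2 to compound 3 (0.12 log units; within the scatter) so with the fluoro group present, this change does not clearly separate the two compounds. Fluoro in place of hydrogen on an aromatic carbon, with the 3,5-dimethoxyphenyl group held constant, gives a 4.1-fold higher number from compound 1 to compound 3 (0.62 log units; beyond the scatter) and this modest step is the one of the two that lies beyond the scatter. Nothing available here explains why these two changes differ in size.

The 4-methoxyphenyl group appears only alongside the fluoro group in the compounds shown, so it remains open whether swapping it for 3,5-dimethoxyphenyl would also stay within the scatter with hydrogen in place of fluoro. Also open, going by these compounds, is how this read-out would respond to a different group on that aromatic carbon, such as chloro, methoxy or an amine, or to a carboxylic acid on the ring attached to the nitrogen.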